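This account rests on a few compounds, and the source may have more. Where it says the series, first, only, none or still open, it means among the compounds named here.

Working notes on the series in an ADME assay on BEAS-2B cells (Homo sapiens) for cytotoxicity, read by MTT assay, with a stated time of 72 h; a higher number here means a weaker inhibitor of growth, a lower number a stronger inhibitor of growth.

Compound 3 `CSc1ccc(CNc2nc(SC)nc3ccccc23)cc1` stands at the highest of the two numbers available: in this assay compound 3 gives 22700 nM. Compound 2 `CSc1ccc(CNc2nc([SeH])nc3ccccc23)cc1` is its nearest neighbour, and in this assay compound 2 gives 410 nM. Going by the values given here, the step between them, a 55-fold higher number from compound 2 to compound 3 (1.74 log units; beyond the scatter), is the only measured step that touches the same place on the shared core. Compound 1 `COc1ccc(CNc2nc([Se]C)nc3ccccc23)cc1` carries the methylselanyl group of compound 4 on a different phenyl ring. In this assay compound 1 reaches only a limit, > 100000 nM, and the limit of > 100000 nM in this assay, at which 1 of the 3 values shown sits, is all that is known for it.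

Compound 4 `CSc1ccc(CNc2nc([Se]C)nc3ccccc23)cc1` is not yet measured. It differs from compound 3 by a group of 2 heavy atoms (1 carbon, 1 selenium; no ring) in place of a group of 2 heavy atoms (1 carbon, 1 sulfur; no ring), on an aromatic carbon. Among the compounds with values here, no measured step covers this exact exchange; the large step from the selenol of compound 2 argues that the selenium-bearing groups can move the number far, while the limit of compound 1 shows a methylselanyl compound at the top of the scale. The expected step of a 1.1-fold lower number from compound 3 to compound 4 (0.05 log units; within the scatter) is therefore taken as small, within the scatter, and compound 4 is estimated at 20000 nM with a range from 5000 nM to 100000 nM.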

Compound 4, concentration for 50% growth inhibition: 35900 nM
The estimate for compound 4 lay 1.8-fold (0.25 log units) below the measured number; the measured number falls inside the stated range.
By their numbers in this assay, from the lowest: compound 2; then compounds 3 and 4 (each within the scatter of the next). At a limit, above all of these: compound 1.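

In this assay, methylselanyl in place of methylsulfanyl on this aromatic carbon between two ring nitrogen atoms leaves the number unmoved: a 1.6-fold higher number from compound 3 to compound 4 (0.20 log units; within the scatter). Methyl in place of hydrogen on the selenium gives an 88-fold higher number from compound 2 to compound 4 (1.94 log units; beyond the scatter), so the large change at this position follows the free selenol of compound 2 and not the exchange of selenium for sulfur in the methyl-capped groups. Methylsulfanyl in place of methoxy on an aromatic carbon gives an at least 2.7-fold lower number from compound 1 to compound 4 (0.44 log units; beyond the scatter), a step read against a limit for compound 1: the limit of > 100000 nM in this assay, at which 1 of the 4 values shown sits.

Going by these compounds, whether a thiol at this position would stand with compound 2 or with compound 3 remains open. Also open, on these data alone, is whether an amine or a longer chain on the selenium would keep the number close to that of compound 4.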